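The source may report more compounds than this note shows. Statements on the series, on what has been measured and on what is new or still open speak of the compounds shown alone.

Measured in a functional assay on HepG2 cells (Homo sapiens), read by MTT assay, with a stated time of 48 h; a lower number here means a stronger inhibitor, a higher number a weaker inhibitor:
- compound 1 `CCN(CC)CCNC(=O)c1ccc(C(CC)(CC)c2ccc(OCC(=O)C(C)(C)C)c(C)c2)n1CC`: 620 nM
- compound 2 `CCn1c(C(=O)NCCN(C)C)ccc1C(CC)(CC)c1ccc(OCC(O)C(C)(C)C)c(C)c1`: 870 nM

Within the data shown here, compound 2 stands at 870 nM, and compound 1 at 620 nM lies within the scatter of it, so the two values mark a single level for the series so far. Compound 3 `C=CCN(C)C(=O)c1ccc(C(CC)(CC)c2ccc(OCC(O)C(C)(C)C)c(C)c2)n1CC` keeps the rest of compound 2 and alters only the amide: allyl(methyl)amino in place of (2-(dimethylamino)ethyl)amino on a carbonyl carbon. Among the measured compounds shown here, no measured pair covers this change, so its size is uncertain and the range must stay wide. A moderate move toward a weaker inhibitor is expected, starting from compound 2 at 870 nM. The estimated step is a 1.8-fold higher number from compound 2 to compound 3 (0.26 log units; within the scatter). For compound 3 the estimated value in this assay is 1600 nM, with an expected range of 500 nM to 6000 nM.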

Compound 3, half-maximal inhibitory concentration: > 50000 nM
Compound 3 was reported as a limit (the forecaster's own chance of this, stated with the estimate: 10%); at least 31-fold (1.49 log units) between middle value and limit.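

In this assay, the amide emerges as a position where the choice of group matters greatly: allyl(methyl)amino in place of (2-(dimethylamino)ethyl)amino on a carbonyl carbon gives an at least 57-fold higher number from compound 2 to compound 3 (1.75 log units; beyond the scatter). Compound 3 is reported as a limit and not as a number, so this step is a minimum: the limit of > 50000 nM in this assay, at which 1 of the 3 values shown sits.

The change replaces the dimethylamino end of the chain and removes the amide hydrogen in one move, so the step cannot be assigned to either alone. As far as these compounds go, a (2-(dimethylamino)ethyl)(methyl)amino group on the same carbonyl carbon would separate the two, and that comparison remains open. Also open, from the compounds shown here alone, is whether a longer chain ending in an amine, such as (3-(dimethylamino)propyl)amino, stays near compound 2 at 870 nM in this assay.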